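The compounds below may be only part of what the source reports. "The series", "measured", "known", "first", "only" and "open" are said of these compounds alone.

Measured compounds:
compound 1, `COc1ccc(CN(C(=O)Nc2ccc(F)c(Cl)c2)n2cnnc2)cc1OC`: 30100 nM
compound 2, `Cc1ccsc1CN(C(=O)Nc1ccccc1)n1cnnc1`: > 50000 nM

In a functional assay on MCF7 cells (Homo sapiens) for cytotoxicity, read by MTT assay, with a stated time of 48 h (on this read-out lower numbers stand for stronger inhibition and higher numbers for weaker inhibition), compound 1 gives 30100 nM. Compound 2 gives no number in this assay, only (the limit of > 50000 nM in this assay, at which 1 of the 2 values shown sits), which is a limit of the assay and not a measured value. Compound 2 therefore stands at the edge of what this assay reports, and compound 1 also shows only weak inhibition.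

Compound 3, `N#Cc1ccc(CN(C(=O)Nc2ccccc2)n2cnnc2)cc1`, is not yet measured. It differs from compound 2 by 4-cyanophenyl in place of 3-methylthiophen-2-yl on a saturated chain carbon bound to an amide-type nitrogen. Within the data shown here, no step between measured compounds is available for this change, so nothing in the two measured values points in either direction. For compound 3 the expected step is an at least 1.1-fold lower number from compound 2 to compound 3 (0.04 log units; that floor lies within the scatter), none beyond the scatter, with a real chance that again only a limit is reported. Compound 3 is estimated at 45000 nM, with a range from 15000 nM to 100000 nM.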

Compound 3, half-maximal inhibitory concentration: > 50000 nM
Compound 3: a limit, no number (the forecaster's own chance of this, stated with the estimate: 55%); middle value at least 1.1-fold (0.04 log units) from the limit.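

No step can be read from compound 2 to compound 3, since in this assay both give only a limit and no number: the limit of > 50000 nM in this assay, at which 2 of the 3 values shown sit.

Still open, going by these compounds, is how far 4-cyanophenyl and 3-methylthiophen-2-yl on a saturated chain carbon bound to an amide-type nitrogen differ in this read-out, if they differ at all.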